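From Cyclohexyl to Piperidin-1-yl: a Solubility Outlook

This account rests on a few compounds, and the source may have more. Where it says the series, first, only, none or still open, it means among the compounds named here.

Compound 1 `CC(C)(C)c1cc(NC(=O)[C@@H]2CCCCN2CC2CCOCC2)no1`: 72 ug/mL
Compound 2 `CC(C)(C)c1cc(NC(=O)[C@@H]2CCCCN2C(=O)C2CCCCC2)no1`: 6.4 ug/mL

In a physicochemical assay for solubility, read by HPLC, at pH 6.8 (a higher number here means a more soluble compound, a lower number a less soluble compound), compound 2 gives the lowest of the two numbers, with compound 1 sitting an 11-fold lower number from compound 1 to compound 2 (1.05 log units; beyond the scatter) reversed above it. Compound 3 `CC(C)(C)c1cc(NC(=O)[C@@H]2CCCCN2C(=O)N2CCCCC2)no1` differs from compound 2 by piperidin-1-yl in place of cyclohexyl on a carbonyl carbon. Among the compounds with values here, the only measured step, an 11-fold lower number from compound 1 to compound 2 (1.05 log units; beyond the scatter), swapped an alkyl group for an acyl group on the ring nitrogen, a different kind of change, so it bears only loosely here. The step is expected to be small, near the scatter, and modestly upward: a 1.9-fold higher number from compound 2 to compound 3 (0.27 log units; within the scatter). Compound 3 is therefore expected to give about 12 ug/mL, within 4 ug/mL to 40 ug/mL.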

Compound 3, solubility: 49 ug/mL
For compound 3 the middle estimate is 4.1-fold (0.61 log units) below the measured one; measured number above the stated range.
By their numbers in this assay, from the lowest: compound 2; then compounds 3 and 1 (each within the scatter of the next).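

On a carbonyl carbon, exchanging one ring carbon for nitrogen, as in piperidin-1-yl in place of cyclohexyl with the heavy-atom count unchanged, gives a 7.7-fold higher number from compound 2 to compound 3 (0.88 log units; beyond the scatter) in this assay. The step from (oxan-4-yl)methyl to (piperidin-1-yl)carbonyl on the amine nitrogen in a ring, a 1.5-fold lower number from compound 1 to compound 3 (0.17 log units; within the scatter), shows that a carbonyl there does not by itself go with a low number. No measurement here explains the difference between cyclohexyl and piperidin-1-yl. From the compounds shown here alone, how a morpholin-4-yl or dimethylamino group on that carbonyl carbon would read remains open.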